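This account rests on a few compounds, and the source may have more. Where it says the series, first, only, none or still open, it means among the compounds named here.

Values in an in vitro ADME assay on microsomes from liver (Homo sapiens) for metabolic stability; on this read-out higher numbers stand for fast clearance and lower numbers for slow clearance:
- compound 1 `O=C(C=C1CCN(C(=O)c2ccccc2O)CC1)N[C@@H]1CCN(Cc2ccc3cc(F)ccc3c2)C1`: < 64 mL/min/kg (a limit of the assay, not a number)
- compound 2 `O=C(C=C1CCN(C(=O)c2ccccc2F)CC1)N[C@@H]1CCN(Cc2ccc3cc(F)ccc3c2)C1`: 590 mL/min/kg
- compound 3 `COc1ccc(C(=O)N2CCC(=CC(=O)N[C@@H]3CCN(Cc4ccc5cc(F)ccc5c4)C3)CC2)cc1OC`: 246 mL/min/kg

Of the two values that are actual numbers, the lower belongs to compound 3, and a 2.4-fold lower number from compound 2 to compound 3 (0.38 log units; beyond the scatter) lies beyond the scatter. The next change leads to compound 4 `O=C(C=C1CCN(C(=O)c2ccc(Cl)cc2O)CC1)N[C@@H]1CCN(Cc2ccc3cc(F)ccc3c2)C1`: 4-chloro-2-hydroxyphenyl in place of 3,4-dimethoxyphenyl on a carbonyl carbon. In words, this is 4-chloro-2-hydroxyphenyl in place of 3,4-dimethoxyphenyl on a carbonyl carbon.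

The closest measured step is an at least 3.8-fold higher number from compound 1 to compound 3 (0.58 log units; beyond the scatter), which runs the other way and involves a 2-hydroxyphenyl group without the chloro group. an at least 9.2-fold higher number from compound 1 to compound 2 (0.96 log units; beyond the scatter) also shows a higher number once hydroxy is replaced, and none of the three compounds goes against this pattern. Within the data shown here, no measured step covers the chloro group, so the size remains uncertain.

A lower number in this assay is therefore expected, given compound 1 and an at least 3.8-fold higher number from compound 1 to compound 3 (0.58 log units; beyond the scatter). The expected change is a 3.1-fold lower number from compound 3 to compound 4 (0.49 log units; beyond the scatter). For compound 4 the estimated value is 80 mL/min/kg, with an expected range from 30 mL/min/kg to 220 mL/min/kg.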

Compound 4, clearance: 87 mL/min/kg
Compound 4: the middle estimate sits 1.1-fold (0.04 log units) below what was measured, within the range that was stated.
By their numbers in this assay, from the lowest: compound 4; then compound 3; then compound 2. At a limit, below all of these: compound 1.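

In this assay the 4-chloro-2-hydroxyphenyl group on the carbonyl carbon gives a 2.8-fold lower number from compound 3 to compound 4 (0.45 log units; beyond the scatter) and also a 6.8-fold lower number from compound 2 to compound 4 (0.83 log units; beyond the scatter) in the same read-out. Compound 4 is thus the only compound shown with a hydroxy group that carries an actual number, and that number lies beyond the scatter from both compounds without a hydroxy group. The chloro step, an at least 1.3-fold higher number from compound 1 to compound 4 (0.13 log units; that floor lies within the scatter) gives only a floor and cannot be read as a size, as one end of it is a limit and not a number: the limit of < 64 mL/min/kg in this assay, at which 1 of the 4 values shown sits.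

Left open is whether the chloro group changes this read-out at all, since the hydroxy compounds shown offer no pair with two actual numbers. Also open, on these data alone, is how an amine or a carboxylic acid in place of the hydroxy group would read here.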